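Swapping an Oxadiazole for an Oxime: Expected Cytotoxicity

The source may hold more compounds than are shown below. What is called first, only, known or untested is meant among the compounds shown, and "the series" means these compounds.

Compound 1 `CCO/N=C/c1ccc(OCCC(C)CCN2CCN(c3cccc(N)c3)C2=O)cc1`: > 100000 nM
Compound 2 `Cc1nc(-c2ccc(OCCC(C)CCN3CCN(c4ccnc(N)c4)C3=O)cc2)no1`: 66100 nM
Compound 3 `CC(=O)Nc1cc(N2CCN(CCCCCOc3ccc(-c4noc(C)n4)cc3)C2=O)ccn1`: > 100000 nM

Among the compounds with values here, in an ADME assay on RD cells (Homo sapiens) for cytotoxicity, read by MTT assay, with a stated time of 24 h (a higher number here means that more compound is tolerated, a lower number that less compound is tolerated), compound 2 gives 66100 nM, the only real number among the three. For compound 1 the value > 100000 nM is a limit of the assay, not a number. For compound 3 the value > 100000 nM is likewise a limit. Within the data shown here, compound 2 thus stands as the single compound resolved by this assay, the others sitting at the limit of > 100000 nM in this assay, at which 2 of the 3 values shown sit.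

Compound 4 `CC(CCOc1ccc(/C=N/O)cc1)CCN1CCN(c2ccnc(N)c2)C1=O` differs from compound 2 by a group of 3 heavy atoms (1 carbon, 1 nitrogen, 1 oxygen; no ring) in place of a group of 6 heavy atoms (3 carbon, 2 nitrogen, 1 oxygen; one five-membered aromatic ring with 3 hetero atoms), on an aromatic carbon. Among the measured compounds shown here, no measured pair tells how such a change acts in this assay, so any expectation rests only on the three values shown. A modest step upward from compound 2, roughly at the edge of the scatter and possibly reaching the limit, is expected. For compound 4 the estimated value is 90000 nM, with a range from 40000 nM to 200000 nM. This estimate corresponds to a step of a 1.4-fold higher number from compound 2 to compound 4 (0.13 log units; within the scatter).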

Compound 4, half-maximal cytotoxic concentration: > 100000 nM
Compound 4: only a limit was reported (the forecaster's own chance of this, stated with the estimate: 55%); middle value at least 1.1-fold (0.04 log units) away from the limit.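

For compound 4 the value > 100000 nM is a limit of the assay, not a number. In this assay, within the data shown here, the first measured pair at this position shows that replacing the 5-methyl-1,2,4-oxadiazol-3-yl with the smaller group without a ring gives an at least 1.5-fold higher number from compound 2 to compound 4 (0.17 log units; that floor lies within the scatter). The true size of this step stays unknown because the value of compound 4 is only a limit, and compound 2 remains the only compound with a real number: the limit of > 100000 nM in this assay, at which 3 of the 4 values shown sit.

On these data alone, whether the step is larger than this floor remains open. So does how an amine or a carboxylic acid on this aromatic carbon would compare with compound 2.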